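The source may hold more compounds than are shown below. What is called first, only, known or untested is meant among the compounds shown, and "the series" means these compounds.

Measured so far:
- compound 1, `CS(=O)(=O)c1ccc(C(=O)N2CCC(C(=O)N3CCN(c4ccc(F)cc4)CC3)CC2)cc1[N+](=O)[O-]`: > 60000 nM
- compound 2, `CS(=O)(=O)c1ccc(C(=O)N2CCC(C(=O)N(Cc3ccccc3)Cc3ccccc3)CC2)cc1[N+](=O)[O-]`: > 60000 nM

Compound 1 has been tested in an assay on isolated protein for inhibition of thyroid hormone receptor alpha (Homo sapiens), read by fluorescence polarization (a lower number here means a stronger inhibitor, a higher number a weaker inhibitor), and the result is not a number but a limit of the assay: compound 1 reaches only > 60000 nM. Compound 2, which shares the core of compound 1 and carries two benzyl groups on the outer amide nitrogen instead of the arylpiperazine, stands at the same point in this assay. The value of compound 2, > 60000 nM, is also a limit. What the two values show is told in one line: the limit of > 60000 nM in this assay, at which 2 of the 2 values shown sit. Among the compounds with values here, no step between measured compounds can therefore be sized here.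

Compound 3, `CS(=O)(=O)c1ccc(C(=O)N2CCC(C(=O)N3CCN(c4ccccc4)CC3)CC2)cc1[N+](=O)[O-]`, has not yet been measured in this assay. Its difference from compound 1 is small: hydrogen in place of fluoro on an aromatic carbon, or, cut one bond further out, 4-fluorophenyl to phenyl. Within the data shown here, with compound 1 at a limit and no measured step to lean on, no movement beyond the scatter is expected in this assay, and the estimate for compound 3 is expected to sit again at the edge of what the assay reports: compound 3 is estimated at 80000 nM, within 30000 nM to 200000 nM, an expected step that the limit leaves unreadable from compound 1 to compound 3.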

Compound 3, half-maximal inhibitory concentration: > 60000 nM
Compound 3 gave a limit, no number (the forecaster's own chance of this, stated with the estimate: 85%); the middle value is on the limit's open side.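

No step between compound 1 and compound 3 can be read, because both values are limits of the assay and not numbers, and all the compounds shown sit at the same one: the limit of > 60000 nM in this assay, at which 3 of the 3 values shown sit.

The compounds shown leave open whether any change to the shared core or its outer amide group would give a readable value in this assay, and whether the fluoro group on compound 1 makes any difference there.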